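The compounds below may be only part of what the source reports. "The series", "measured", "known", "first", "only" and "open" are said of these compounds alone.

Measured so far in an assay on CHO-K1 cells for displacement of a labelled ligand from adenosine receptor A1 (Homo sapiens), read by scintillation counting, with a stated time of 60 min; on this read-out higher numbers stand for weaker inhibition and lower numbers for stronger inhibition:
compound 1, `Nc1nc(N/N=C/c2cncs2)nc2c1ncn2[C@@H]1O[C@H](CO)[C@@H](O)[C@H]1O`: 22 nM
compound 2, `Nc1nc(N/N=C/c2ccc(-c3ccc(Br)cc3)o2)nc2c1ncn2[C@@H]1O[C@H](CO)[C@@H](O)[C@H]1O`: 4.5 nM
compound 3, `Nc1nc(N/N=C/c2ccc(OCc3ccccc3)c(OCc3ccccc3)c2)nc2c1ncn2[C@@H]1O[C@H](CO)[C@@H](O)[C@H]1O`: > 10000 nM (a limit, not a number)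

Compound 1 holds the higher of the two numbers that the series gives in this assay; compound 2 gives the lower number, and the gap between the two lies beyond the usual scatter. Compound 3 sits at the limit of > 10000 nM in this assay, at which 1 of the 3 values shown sits, which is a limit of the assay and not a number, so it gives no foothold for comparison. Going by the values given here, no two measured compounds differ in one place only, so no measured step is available.

Compound 4, `Nc1nc(N/N=C/c2ccc[nH]2)nc2c1ncn2[C@@H]1O[C@H](CO)[C@@H](O)[C@H]1O`, is not yet measured. It differs from compound 1 by 1H-pyrrol-2-yl in place of 1,3-thiazol-5-yl on a carbon with a double bond to nitrogen. Both groups are five-membered aromatic rings of the same heavy-atom count, so on this change alone the expected step is a 1.4-fold higher number from compound 1 to compound 4 (0.13 log units; within the scatter), that is, none beyond the scatter; the direction cannot be read from the measured compounds. The estimate for compound 4 in this assay is therefore 30 nM, with a range from 8 nM to 120 nM.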

Compound 4, inhibition constant: 8 nM
Estimate against measurement, compound 4: 3.8-fold (0.57 log units) above; the measured number falls inside the stated range.
By their numbers in this assay, from the lowest: compounds 2 and 4 (each within the scatter of the next); then compound 1. At a limit, above all of these: compound 3.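

In this assay, going by these compounds alone, 1H-pyrrol-2-yl in place of 1,3-thiazol-5-yl on a carbon with a double bond to nitrogen gives a 2.8-fold lower number from compound 1 to compound 4 (0.44 log units; beyond the scatter) and is the first measured single-place step. This place therefore responds modestly to an exchange between two five-membered aromatic rings with the same heavy-atom count, where the entering ring carries a hydrogen-bond donor that the leaving ring lacks and has no sulfur. No measurement shown accounts for the step.

Still open, going by these compounds, is whether the step follows the ring hydrogen-bond donor or the loss of sulfur, a question that a furan-2-yl or a 1-methyl-1H-pyrrol-2-yl group in the same place would address. Also open, on these data alone, is whether a six-membered ring such as phenyl would be tolerated there.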